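The source may hold more compounds than are shown below. What is called first, only, known or untested is meant among the compounds shown, and "the series" means these compounds.

Measured in a functional assay on MCF7 cells (Homo sapiens) for antiproliferative activity, read by sulforhodamine B assay, with a stated time of 48 h; on this read-out lower numbers stand for stronger inhibition and higher numbers for weaker inhibition:
Compound 1 `Cc1cccc(NS(=O)(=O)c2ccc(N3CCNC3=O)cc2)c1`: 190 nM
Compound 2 `CC(C)(C)c1ccc(NS(=O)(=O)c2ccc(N3CCNC3=O)cc2)cc1`: > 1000 nM

For the measured compounds named here, compound 1 holds the only true number in this small set. The entry for compound 2 is a limit of the assay and not a number: > 1000 nM.

Compound 3 `O=C1NCCN1c1ccc(S(=O)(=O)Nc2ccc(F)c(F)c2)cc1` has not yet been measured in this assay. It keeps the core of compound 1 and has 3,4-difluorophenyl in place of 3-methylphenyl on a sulfonamide nitrogen.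

Going by the values given here, no measured step covers this exchange, so the expectation rests on compound 1 and its 190 nM. A shift no larger than the usual scatter is expected, with a slight lean towards weaker inhibition. The estimated step is a 1.3-fold higher number from compound 1 to compound 3 (0.12 log units; within the scatter). For compound 3 the expected value is 250 nM. The estimated range for this value runs from 70 nM to 900 nM.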

Compound 3, half-maximal inhibitory concentration: 620 nM
Compound 3: middle estimate off by 2.5-fold (0.39 log units), on the low side; low and high end bracket the measured number.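

Putting 3,4-difluorophenyl in place of 3-methylphenyl on the sulfonamide nitrogen gives a 3.3-fold higher number from compound 1 to compound 3 (0.51 log units; beyond the scatter) in this assay and so shows that the read-out responds to this exchange, here towards weaker inhibition. For the compounds shown here, compound 2 holds only a limit of the assay, so this is the first change at this place whose size can be read. The room left on the weaker side is short in this small set: the limit of > 1000 nM in this assay, at which 1 of the 3 values shown sits.

On these data alone, whether the shift goes with the arrival of the two fluorines or with the departure of the methyl stays open, and plain phenyl or 3-fluorophenyl on that nitrogen would speak to it. Also open, as far as these compounds go, is how a group of another kind on the phenyl ring, such as an amine or a carboxylic acid, would read in this assay on this core.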